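Methylsulfonyl Takes the Place of Dimethylamino

A few compounds are considered here, and "the series" means these few. Any claim that something is new, unique, unknown or untested is made for them only; others in the source may bear on it.

Of the compounds shown here, three sharing one core have been tested in an assay for binding affinity to dual specificity mitogen-activated protein kinase kinase 4 (Homo sapiens), read by KINOMEscan, tested at 100 nM; a lower number here means a stronger effect, a higher number a weaker effect of the compound at the concentration tested. Compound 1 `CCCS(=O)(=O)Nc1ccc(F)c(C(=O)c2n[nH]c3ncc(-c4ccc(F)cc4)cc23)c1F` gives 2.1%. Compound 2 `CCCS(=O)(=O)Nc1ccc(F)c(C(=O)c2n[nH]c3ncc(-c4ccccc4N)cc23)c1F` gives 23%. Compound 3 `CCCS(=O)(=O)Nc1ccc(F)c(C(=O)c2n[nH]c3ncc(-c4ccc(N(C)C)cc4)cc23)c1F` gives 2.5%. Among these three numbers compound 3 stands second highest: its nearest neighbour is compound 1, with a number 0.4 percentage points higher from compound 1 to compound 3 (within the scatter), a difference that lies within the scatter, while the furthest is compound 2, with a number 20.5 percentage points lower from compound 2 to compound 3 (beyond the scatter). The step of a number 20.9 percentage points higher from compound 1 to compound 2 (beyond the scatter) shows that altering the group on the outer ring can matter, whereas the change leading to compound 3 did not.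

Compound 4 `CCCS(=O)(=O)Nc1ccc(F)c(C(=O)c2n[nH]c3ncc(-c4ccc(S(C)(=O)=O)cc4)cc23)c1F` is not yet measured. It differs from compound 3 in one place: methylsulfonyl in place of dimethylamino on an aromatic carbon. Going by the values given here, only one measured step bears directly on this position of the outer ring, namely a number 0.4 percentage points higher from compound 1 to compound 3 (within the scatter), which stayed within the scatter when fluoro became dimethylamino. Compound 2 carries its change at another place and does not speak to this one. On this basis the expected step of a number 2.5 percentage points higher from compound 3 to compound 4 (within the scatter) is small, with any drift toward a higher number likely to stay modest. Compound 4 is therefore estimated at 5%, with a likely range from 1% to 20%.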

Compound 4, a percentage reported as activity, at one concentration (the size of the read-out at that concentration, not a potency): 1.5%
For compound 4 the middle estimate is 3.5 percentage points above the measured one; the range from low to high includes it.
By their numbers in this assay, from the lowest: compounds 4, 1 and 3 (each within the scatter of the next); then compound 2.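

In this assay the change to methylsulfonyl gives a number 1 percentage points lower from compound 3 to compound 4 (within the scatter) and, measured against fluoro at the same place, a number 0.6 percentage points lower from compound 1 to compound 4 (within the scatter) so fluoro, dimethylamino and methylsulfonyl on this aromatic carbon, para to a large group, now all read alike within the scatter. Dimethylamino alone could not show that a group with a sulfur and two oxygens would fit the same pattern, so the range of groups compatible with a low number at this place is wider than the earlier compounds showed, while the step of a number 21.5 percentage points lower from compound 2 to compound 4 (beyond the scatter) keeps compound 2 with its 2-aminophenyl ring apart from the other three. Nothing measured here explains why these different groups give such similar numbers.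

A plain amine at this place, giving a 4-aminophenyl ring, would help separate the effect of the amine group itself from that of where it sits on the ring, and a carboxylic acid would test this tolerance with a quite different group. Since these numbers come from a single concentration, they show only the size of the effect at that concentration, and compounds 1, 3 and 4 could still differ in a stronger or weaker effect at other concentrations, which only measurements at further concentrations could bring out.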